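This account rests on a few compounds, and the source may have more. Where it says the series, first, only, none or still open, it means among the compounds named here.

Measured compounds:
Compound 1 `CCOC(=O)Cn1ncc2c(Nc3ccc(NC(=O)c4ccccc4)cc3)ncnc21`: in a functional assay on cells (Homo sapiens) for inhibition, read by MTT assay, with a stated time of 72 h (on this read-out higher numbers stand for weaker inhibition and lower numbers for stronger inhibition), compound 1 gives > 100 ug/mL, which is a limit of the assay rather than a number.
Compound 2 `CCOC(=O)Cn1ncc2c(Nc3ccc(NC(C)=O)cc3)ncnc21`: in this assay compound 2 gives > 64 ug/mL, which is likewise a limit.

Compound 1 therefore stands at the edge of what this assay can report, at the limit of > 100 ug/mL in this assay, at which 1 of the 2 values shown sits. Among the compounds with values here, the one further value shown is also a limit, at the limit of > 64 ug/mL in this assay, at which 1 of the 2 values shown sits. Within the data shown here, the single measured step, from compound 1 to compound 2, is a step that the two limits leave unreadable from compound 1 to compound 2, so its size stays hidden. Compound 3 `O=C(O)Cn1ncc2c(Nc3ccc(NC(=O)c4ccccc4)cc3)ncnc21` differs from compound 1 by hydrogen in place of ethyl on an oxygen next to a carbonyl group. Among the measured compounds shown here, no measured step touches that position, and the only step there is cannot be read, so nothing in these numbers points to a change in either direction in this assay; the expectation is simply that compound 3 again sits where the assay stops reporting. Compound 3 is estimated at 100 ug/mL, between 30 ug/mL and 300 ug/mL. The step from compound 1 to compound 3 that this estimate means is a number no higher from compound 1 to compound 3 (the limit leaves the size open), expected to be none beyond the scatter.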

Compound 3, half-maximal inhibitory concentration: > 100 ug/mL
Compound 3: only a limit was reported; the forecaster's own chance of this, stated with the estimate: 75%; the middle value sits exactly at the limit.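

Compound 1 and compound 3 are each reported in this assay only as a limit, not a number, so no step between them can be read: the limit of > 100 ug/mL in this assay, at which 2 of the 3 values shown sit.

The compounds shown leave open how strongly any of them inhibits, and whether hydrogen in place of ethyl on an oxygen next to a carbonyl group changes inhibition at all.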